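The compounds below may be only part of what the source reports. "The series", "measured", "known", "first", "only" and "open" are said of these compounds alone.

Measured so far in an assay on cell membranes for displacement of a labelled ligand from corticotropin-releasing factor receptor 1 (Rattus norvegicus); a higher number here means a weaker inhibitor, a lower number a stronger inhibitor:
compound 1 `CCOCC(COCC)Nc1nc(C)nc2c(-c3ccc(OC)cc3C)c(C)nn12`, 19.3 nM
compound 2 `COc1cc(C)c(-c2c(C)nn3c(NC4CCC4)nc(C)nc23)c(OC)c1`, 17.4 nM

Of the two numbers, that of compound 2 is the lower, yet the gap to compound 1 lies within the usual scatter of repeated measurements, so the two compounds cannot be told apart on these data. Among the compounds with values here, no step between measured compounds that differ in one place has been recorded, so nothing yet shows what removing a methoxy group does.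

Compound 3 `COc1ccc(-c2c(C)nn3c(NC4CCC4)nc(C)nc23)c(C)c1` is the next to be tested in this assay. It differs from compound 2 in one place: hydrogen in place of methoxy on an aromatic carbon.

Within the data shown here, with no measured step to rest on, the expectation for compound 3 is a small change, if any, most likely toward a somewhat higher number, with a step of a 1.4-fold higher number from compound 2 to compound 3 (0.16 log units; within the scatter) judged about as likely as none beyond the scatter. The estimate for compound 3 in this assay is 25 nM, with a range from 8 nM to 75 nM.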

Compound 3, half-maximal inhibitory concentration: 24.6 nM
Estimate against measurement, compound 3: 1.0-fold (0.01 log units) above; measured number inside the range.
By their numbers in this assay, from the lowest: compounds 2, 1 and 3 (each within the scatter of the next).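

In this assay, hydrogen in place of methoxy on an aromatic carbon, ortho to a large group, gives a 1.4-fold higher number from compound 2 to compound 3 (0.15 log units; within the scatter) and so leaves the two compounds unresolved: at this position, the methoxy group is not shown to be needed for binding in this series. Cyclobutyl in place of 2-ethoxy-1-(ethoxymethyl)ethyl on a nitrogen on an aromatic ring gives a 1.3-fold higher number from compound 1 to compound 3 (0.11 log units; within the scatter) as the first readable step at that nitrogen, and these two compounds cannot be told apart either. Nothing at hand gives a reason for either step.

Still open, going by these compounds, is whether a fluorine atom, a hydroxyl group or a longer alkoxy chain at the same aromatic carbon would move the number beyond the scatter. Also open, on these data alone, is what an amine or a carboxylic acid on the nitrogen substituent would do.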